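Adding a Second Hydroxymethyl to a Weak Cytotoxic Scaffold

The compounds below may be only part of what the source reports. "The series", "measured", "known", "first", "only" and "open" are said of these compounds alone.

Measured compounds:
Compound 1, `COC(=O)c1cc2n(c1C)[C@@H](c1ccccc1)SC2`: 40900 nM
Compound 2, `Cc1c(CO)cc2n1[C@@H](c1ccccc1)SC2`: 11000 nM
Compound 3, `Cc1cc(CO)c2n1[C@@H](c1ccccc1)SC2`: 65100 nM

These three compounds share one bicyclic core and were tested in a functional assay on WiDr cells (Homo sapiens) for cytotoxicity, read by MTT assay, with a stated time of 96 h; a higher number here means a weaker inhibitor, a lower number a stronger inhibitor. Compound 3 gives 65100 nM, the highest of the three numbers. It sits within the scatter of compound 1, which gives 40900 nM. Compound 2 gives 11000 nM. The gap between compound 3 and compound 2 lies beyond the scatter.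

Compound 4, `Cc1c(CO)c(CO)c2n1[C@@H](c1ccccc1)SC2`, is the next step. Relative to compound 3 the change is hydroxymethyl in place of hydrogen on an aromatic carbon.

Within the data shown here, only one measured step exists, and it concerns a different change: a 3.7-fold lower number from compound 1 to compound 2 (0.57 log units; beyond the scatter). Among the measured compounds shown here, no measured pair shows a hydroxymethyl replacing a hydrogen, so that step gives indirect guidance at most. Compound 2, which already carries a hydroxymethyl group on the carbon that gains one here, gives the lowest number of the three, while compound 3 gives the highest; compound 4 combines both groups.

On this basis a modest lowering of the number is expected for compound 4, a 1.9-fold lower number from compound 3 to compound 4 (0.27 log units; within the scatter), with wide uncertainty. The estimate for compound 4 in this assay is 35000 nM, within a range from 10000 nM to 100000 nM.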

Compound 4, half-maximal inhibitory concentration: 3200 nM
Estimate against measurement, compound 4: 11-fold (1.04 log units) above, and the stated range ends above it.
By their numbers in this assay, from the lowest: compound 4; then compound 2; then compounds 1 and 3 (each within the scatter of the next).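

Within this assay, putting hydroxymethyl in place of hydrogen on this aromatic carbon, which lies next to the ring atom that bears a methyl group, gives a 20-fold lower number from compound 3 to compound 4 (1.31 log units; beyond the scatter) and counts as a large step, the first measured case of this swap on the shared core. The same kind of swap, starting instead from compound 2, gives a 3.4-fold lower number from compound 2 to compound 4 (0.54 log units; beyond the scatter) and counts as a modest step, so compound 4, with both hydroxymethyl groups, has a lower number than either compound carrying one of them, and both steps lie beyond the scatter. Nothing shown gives a measured reason for this gain from a second hydroxymethyl group.

The compounds shown leave open which part of the new group matters at this carbon: a methoxymethyl group, an aminomethyl group, a carboxylic acid or a longer chain such as hydroxyethyl would each separate a different feature of hydroxymethyl. They also leave open whether the same gain would survive a change elsewhere, because the methyl and phenyl groups stay the same across compound 2, compound 3 and compound 4.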